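Cyclopropylaminopurine glycinamide esters: side-chain exchange at the amino-acid carbon

This account rests on a few compounds, and the source may have more. Where it says the series, first, only, none or still open, it means among the compounds named here.

Measured so far:
compound 1 `O=C(CN(c1nc(Cl)nc2[nH]cnc12)C1CC1)N[C@@H](CO)C(=O)OCc1ccccc1` — 34.5%
compound 2 `N=C(N)NCCC[C@H](NC(=O)CN(c1nc(Cl)nc2[nH]cnc12)C1CC1)C(=O)OCc1ccccc1` — 10.2%

Both were run in a functional assay on the whole organism (Tail, strain ICR) with Mus musculus as the target, in the tail flick test, with a stated time of 120 min, at a dose of 25 umol/kg by the oral route; on this read-out higher numbers stand for a stronger effect at the one dose given and lower numbers for a weaker effect. Compound 2 stands lowest of the two numbers; compound 1 is the nearest, and the step of a number 24.3 percentage points lower from compound 1 to compound 2 (beyond the scatter) is beyond the scatter.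

Compound 3 `CC[C@H](C)[C@H](NC(=O)CN(c1nc(Cl)nc2[nH]cnc12)C1CC1)C(=O)OCc1ccccc1` is not yet measured. It differs from compound 2 by a group of 4 heavy atoms (4 carbon; no ring) in place of a group of 7 heavy atoms (4 carbon, 3 nitrogen; no ring), on a saturated chain carbon bound to an amide-type nitrogen and a carbonyl carbon.

Within the data shown here, no measured step repeats this change. Among the measured compounds shown here, the only step known, a number 24.3 percentage points lower from compound 1 to compound 2 (beyond the scatter), shows that exchanging the group on this chain carbon moves this assay by a modest amount. Removing the entering group of that step is therefore expected to bring compound 3 back toward the level of compound 1, an estimated step of a number 19.8 percentage points higher from compound 2 to compound 3 (beyond the scatter). Compound 3 is expected to give about 30%, within 10% to 55%.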

Compound 3, a percentage reported as activity, at one dose (the size of the read-out at that dose, not a potency): 22%
Beside the measured number, compound 3's estimate is 8 percentage points above it; low and high end bracket the measured number.
By their numbers in this assay, from the lowest: compound 2; then compound 3; then compound 1.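

On the saturated chain carbon bound to an amide-type nitrogen and a carbonyl carbon, sec-butyl lands in the middle of this assay with a number 11.8 percentage points higher from compound 2 to compound 3 (beyond the scatter) and a number 12.5 percentage points lower from compound 1 to compound 3 (beyond the scatter) as its two steps. A side chain with no hydrogen-bond donors or acceptors thus recovers only part of the gap to the hydroxymethyl of compound 1. Nothing available explains this order.

Still open, going by these compounds, is how a carboxylic acid, a primary amine or a longer unbranched alkyl chain on this carbon would rank against these three side chains.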